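Removing 4,6-dimethylpyrimidin-2-yl from a sulfonamide nitrogen

The compounds below may be only part of what the source reports. "The series", "measured", "known", "first", "only" and "open" are said of these compounds alone.

In a functional assay on OVCAR-3 cells (Homo sapiens) for antiproliferative activity, read by sulforhodamine B assay, with a stated time of 72 h (on this read-out higher numbers stand for weaker inhibition and lower numbers for stronger inhibition), compound 1 `Cc1cc(C)nc(NS(=O)(=O)c2ccc(Nc3nncc4ccccc34)cc2)n1` gives 3.4 nM. Compound 2 `C(=C/c1ccccc1)\C(=N\Nc1nncc2ccccc12)c1ccccc1` gives 3.3 nM, so these two sit level within the usual scatter. Compound 3 `O=C1CS/C(=N/Nc2nncc3ccccc23)N1` gives 46 nM, clearly weaker than compound 1 and well beyond the scatter. Compound 1 therefore shares the strong end of this small set with compound 2.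

Compound 4 `NS(=O)(=O)c1ccc(Nc2nncc3ccccc23)cc1` has hydrogen in place of 4,6-dimethylpyrimidin-2-yl on a sulfonamide nitrogen. Going by the values given here, no measured pair isolates this change, so any expectation here is loose. Among the compounds with values here, the only hint comes from compound 3, the smallest measured molecule, at 46 nM, which suggests that a trimmed compound may give up some activity in this assay. The estimated change is a moderate weakening, a 3.5-fold higher number from compound 1 to compound 4 (0.55 log units; beyond the scatter), and it may only just clear the scatter. For compound 4 the estimated value is 12 nM, with an expected range of 3 nM to 60 nM.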

Compound 4, half-maximal inhibitory concentration: 14 nM
Beside the measured number, compound 4's estimate is 1.2-fold (0.07 log units) below it; the range from low to high includes it.
By their numbers in this assay, from the lowest: compounds 2 and 1 (each within the scatter of the next); then compound 4; then compound 3.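

This is the first pair shown that differs in one place only. In this assay, replacing 4,6-dimethylpyrimidin-2-yl on the sulfonamide nitrogen with hydrogen gives a 4.1-fold higher number from compound 1 to compound 4 (0.61 log units; beyond the scatter), so the group adds to the activity, although the step is modest and compound 4 still gives 14 nM without it. No measurement available here explains why removing the group has this effect.

The compounds shown leave open whether a small group on this nitrogen, such as methyl or acetyl, could restore the activity of compound 1, or whether a plain phenyl ring could do the same. They also leave open how much the two methyl groups contribute, a question that an unsubstituted pyrimidin-2-yl group would address.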